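Sulfonamide nitrogen swap in a benzamide series

The source may report more compounds than this note shows. Statements on the series, on what has been measured and on what is new or still open speak of the compounds shown alone.

Compound 1 `COc1ccc(NS(=O)(=O)c2ccc(NC(=O)c3ccc(Cl)cc3Cl)cc2)cc1` is the starting point of this account. In a functional assay on HEK293 cells for agonist activity at probable G-protein coupled receptor 27 (Homo sapiens), read by a luciferase reporter and beta-arrestin recruitment, with a stated time of 10 min (on this read-out lower numbers stand for smaller maximal responses and higher numbers for larger maximal responses), compound 1 gives "not determined" (no result reported), so no single number stands for it, and it cannot be placed against the others on this read-out. The same holds for compound 3 `O=C(Nc1ccccc1)c1ccc(NC(=O)c2ccc(Cl)cc2Cl)cc1`, which in this assay gives "not determined" (no result reported). Among the measured compounds shown here, the only compound with a number is compound 2 `O=C(Nc1ccc(S(=O)(=O)Nc2ccccc2)cc1)c1ccc2ccccc2c1`, which in this assay reaches 115%. Compound 2 and compound 1 differ in more than one place, so their two entries show nothing about any single change.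

Compound 4 `O=C(Nc1ccc(S(=O)(=O)Nc2ccccc2Cl)cc1)c1ccc(Cl)cc1Cl` is to be measured. It differs from compound 1 in one place: 2-chlorophenyl in place of 4-methoxyphenyl on a sulfonamide nitrogen. Since compound 1 has no number in this assay, the size or direction of the step to compound 4 cannot be read from the data, and nothing in the series isolates this change.

What can be said rests on compound 2 alone. Because compound 2, which shares the sulfonamide-linked core, reaches 115%, compound 4 is expected to give a largest response of about 90% in this assay, with a broad range from 40% to 130%.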

Compound 4, largest response reached (Emax), in percent of the reference or control that the assay uses: 53%
Compound 4: middle estimate off by 37 percentage points, on the high side; measured number inside the range.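

No step can be read from compound 1 to compound 4: in this assay compound 1 gives "not determined" (no result reported) and has no number, while compound 4 gives 53% as its largest response. The compounds shown leave open what 2-chlorophenyl in place of 4-methoxyphenyl on a sulfonamide nitrogen does to that response. No measured evidence bears on this result.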